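This account rests on a few compounds, and the source may have more. Where it says the series, first, only, none or still open, it means among the compounds named here.

Three close relatives built on one shared core have so far been examined in an ADME assay; on this read-out lower numbers stand for a shorter-lived compound and higher numbers for a longer-lived compound. Compound 1 `COCOCCOc1cc(OC)ccc1C[S+]([O-])c1ncccc1C(=O)Nc1ccncc1` gives 2.75 h. Compound 2 `CCOc1cc(OC)ccc1C[S+]([O-])c1ncccc1C(=O)Nc1ccncc1` gives 0.71 h, while compound 3 `COc1ccc(C[S+]([O-])c2ncccc2C(=O)Nc2ccncc2)c(OC)c1` gives 0.84 h. Among these numbers compound 3 stands second highest of three; its nearest neighbour is compound 2, which lies within the scatter of it, and its furthest is compound 1, which stands clearly above it as the step of a 3.3-fold lower number from compound 1 to compound 3 (0.52 log units; beyond the scatter) shows.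

The new member, compound 4 `COCOc1cc(OC)ccc1C[S+]([O-])c1ncccc1C(=O)Nc1ccncc1`, differs from compound 3 in a single place: methoxy in place of hydrogen on a saturated chain carbon bound to an oxygen on an aromatic ring.

Going by the values given here, two measured steps bear on this position. Swapping hydrogen for methyl there, the step of a 1.2-fold higher number from compound 2 to compound 3 (0.07 log units; within the scatter), stays within the scatter. Swapping hydrogen for the larger (methoxymethoxy)methyl, the step of a 3.3-fold lower number from compound 1 to compound 3 (0.52 log units; beyond the scatter), lowers the number by a modest amount, so growth at this position has gone with a longer-lived compound once and with no clear change once. Among the compounds with values here, the group entering in compound 4 is smaller than the one in compound 1 but larger than that in compound 2, so a modest rise is expected, with the possibility that it stays within the scatter.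

For compound 4 in this assay a value of 1.4 h is expected, within a range of 0.6 h to 3 h, which amounts to an estimated step of a 1.7-fold higher number from compound 3 to compound 4 (0.22 log units; within the scatter).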

Compound 4, half-life: 8.25 h
Beside the measured number, compound 4's estimate is 5.9-fold (0.77 log units) below it; measured number above the stated range.
By their numbers in this assay, from the lowest: compounds 2 and 3 (each within the scatter of the next); then compound 1; then compound 4.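

Putting methoxy on this saturated chain carbon gives a 9.8-fold higher number from compound 3 to compound 4 (0.99 log units; beyond the scatter) in this assay and a 12-fold higher number from compound 2 to compound 4 (1.07 log units; beyond the scatter) when it replaces methyl, whereas hydrogen and methyl at the same carbon lie within the scatter of each other. Going by these compounds alone, a small change at this carbon can therefore move the number much further than the earlier compounds showed. Those compounds hinted that a larger group here might go with a longer-lived compound, yet a 3.0-fold higher number from compound 1 to compound 4 (0.48 log units; beyond the scatter) places the smaller methoxy above the (methoxymethoxy)methyl of compound 1, so size alone does not put these four compounds in order. Nothing at hand gives a reason for this jump.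

As far as these compounds go, whether the rise depends on an oxygen joined directly to this carbon stays open, and a fluorine atom, a hydroxy group or an amine there would bear on that question. Also open, from the compounds shown here alone, is whether the high number belongs to methoxy alone or extends to a slightly longer group at this carbon, such as ethoxy.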